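From ethyl to phenoxy in a sulfonamide series

The compounds below may be only part of what the source reports. "The series", "measured", "known", "first", "only" and "open" are said of these compounds alone.

Values in a functional assay on MCF7 cells (Homo sapiens) for inhibition, read by CCK-8 assay, with a stated time of 72 h; on this read-out lower numbers stand for stronger inhibition and higher numbers for weaker inhibition:
Compound 1 `Cc1cccc(NS(=O)(=O)c2cccc(CCCCCCNC(=O)/C=C/c3cccnc3)c2)c1`: 4 nM
Compound 2 `CCc1ccc(NS(=O)(=O)c2cccc(CCCCCCNC(=O)/C=C/c3cccnc3)c2)cc1`: 3.64 nM

Within the data shown here, compound 2 gives 3.64 nM in this assay and stands within the scatter of compound 1, the only other compound measured so far. Compound 3 `O=C(/C=C/c1cccnc1)NCCCCCCc1cccc(S(=O)(=O)Nc2ccc(Oc3ccccc3)cc2)c1` differs from compound 2 as follows: phenoxy in place of ethyl on an aromatic carbon. In words, phenoxy takes the place of ethyl on an aromatic carbon, para to a large group. Among the measured compounds shown here, only one measured step bears on this change, a 1.1-fold lower number from compound 1 to compound 2 (0.04 log units; within the scatter), and it involved no group with a ring of its own, so it offers only weak guidance here. A modest weakening is expected, with little confidence in its direction, amounting to a 1.9-fold higher number from compound 2 to compound 3 (0.28 log units; within the scatter) in this assay as the estimated step. For compound 3 the estimated value is 7 nM within an expected range from 1.5 nM to 35 nM as the likely outcome.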

Compound 3, half-maximal inhibitory concentration: 3.84 nM
The estimate for compound 3 lay 1.8-fold (0.26 log units) above the measured number, and the stated range covers the measured number.
By their numbers in this assay, from the lowest: compounds 2, 3 and 1 (each within the scatter of the next).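

Among these compounds, the step of a 1.1-fold higher number from compound 2 to compound 3 (0.02 log units; within the scatter) in this assay gives the first reading of a group with a ring of its own at this aromatic carbon, para to a large group. Phenoxy, with its seven heavy atoms and one six-membered aromatic ring, reads the same within the scatter as ethyl, with its two heavy atoms and no ring, so this added bulk leaves no measurable mark on the number here. Nothing measured here speaks to why the two groups read alike.

The compounds shown leave open whether this aromatic carbon would accept just as readily an amine or a carboxylic acid in place of phenoxy. They also leave open whether a larger ring system, such as naphthyloxy, would still read within the scatter of compound 3.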